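The compounds below may be only part of what the source reports. "The series", "measured", "known", "first", "only" and "open" are said of these compounds alone.

Compound 1, with the structure `CCC(=O)Nc1cccnc1NCc1ccc(-c2ccccc2C(=O)OC)cc1`, is the starting point of this series. In an in vitro assay on CHO cells for inhibition of B1 bradykinin receptor (Homo sapiens) (a higher number here means a weaker inhibitor, a lower number a stronger inhibitor), compound 1 gives 119 nM. Compound 2, `COC(=O)c1ccccc1-c1ccc(CNc2ncccc2NC(=O)C(C)C)cc1`, carries methyl in place of hydrogen on a saturated chain carbon bound to a carbonyl carbon and a saturated chain carbon relative to compound 1; in this assay compound 2 gives 230 nM, and the step of a 1.9-fold higher number from compound 1 to compound 2 (0.29 log units; within the scatter) shows that this change left the inhibition constant essentially where it was.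

Compound 3, `COC(=O)c1ccccc1-c1ccc(CNc2nccc(C)c2NC(=O)CC(F)(F)F)cc1`, has a core that differs from compound 1 in more than one place, and the difference between the two cores is not broken down here. In this assay compound 3 gives 7.1 nM, the lowest number of the three measured compounds, with its distance to compound 1 and to compound 2 both beyond the usual scatter.

Compound 4, `COC(=O)c1ccccc1-c1ccc([C@@H](C)Nc2nccc(C)c2NC(=O)CC(F)(F)F)cc1`, has not yet been measured. It differs from compound 3 by methyl in place of hydrogen on a saturated chain carbon bound to an aromatic carbon and a nitrogen on an aromatic ring. Going by the values given here, this is the same kind of change as the one between compound 1 and compound 2, a methyl entering in place of a hydrogen, but at a different place: in compound 2 the methyl sits on a saturated chain carbon bound to a carbonyl carbon and a saturated chain carbon, whereas in compound 4 it sits on a saturated chain carbon bound to an aromatic carbon and a nitrogen on an aromatic ring. Among the compounds with values here, the only measured precedent for adding a methyl, a 1.9-fold higher number from compound 1 to compound 2 (0.29 log units; within the scatter), stayed within the scatter, so a small step is expected from compound 3 to compound 4 as well, estimated at a 1.2-fold lower number from compound 3 to compound 4 (0.07 log units; within the scatter). On that basis compound 4 is expected to give about 6 nM in this assay, most likely between 2 nM and 20 nM.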

Compound 4, inhibition constant: 1.8 nM
Beside the measured number, compound 4's estimate is 3.3-fold (0.52 log units) above it; measured number below the stated range.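

In this assay, methyl in place of hydrogen on a saturated chain carbon bound to an aromatic carbon and a nitrogen on an aromatic ring gives a 3.9-fold lower number from compound 3 to compound 4 (0.60 log units; beyond the scatter), and this step does not match the earlier methyl step: the same change on two cores in this assay, a 1.9-fold higher number (0.29 log units; within the scatter) from compound 1 to compound 2 and a 3.9-fold lower number (0.60 log units; beyond the scatter) from compound 3 to compound 4, 7.6-fold (0.88 log units) apart, beyond the scatter of two such steps This shows that, across the compounds shown, putting methyl in place of hydrogen does not carry a single fixed step from one core to another, so the earlier step alone gives no reliable size or direction for the next one. It does not show what sets the two steps apart, since the two methyl groups sit at different places and on different cores, each case rests on a single pair, and the data cannot separate the effect of place from that of core.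

Going by these compounds, it remains open whether methyl at this same saturated chain carbon would give a similar step on the core of compound 1, which would separate place from core. Also open, on these data alone, is how an ethyl group at that carbon, or the opposite arrangement of the methyl group there, would compare with compound 4.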